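The compounds below may be only part of what the source reports. "The series", "measured", "known", "first", "only" and "open" are said of these compounds alone.

Compound 2 `CC1(C)N=C(N)N=C(N)N1c1ccc(CCC(=O)Nc2ccc(S(=O)(=O)F)cc2)cc1` is the starting point. In an assay on isolated protein for inhibition of Dihydrofolate reductase (Mus musculus) (on this read-out lower numbers stand for lower potency and higher numbers for higher potency (the scale is a negative logarithm)), compound 2 gives 7.6. Its number sits at the low end of the three measured here, yet neither neighbour is separated from it beyond the scatter: compound 1 `CC1(C)N=C(N)N=C(N)N1c1ccc(CCC(=O)Nc2ccc(S(=O)(=O)F)cc2)c(Cl)c1` gives 7.62 in this assay, and compound 3 `CC1(C)N=C(N)N=C(N)N1c1ccc(CCc2ccc(S(=O)(=O)F)c(Cl)c2)c(Cl)c1` gives 7.85. For the measured compounds named here, the one measured step between single-change neighbours, a number 0.02 log units lower from compound 1 to compound 2 (within the scatter), was within the scatter.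

Compound 4 `CC1(C)N=C(N)N=C(N)N1c1ccc(CCC(=O)Nc2cccc(S(=O)(=O)F)c2)cc1` has the same atoms as compound 2, joined differently: 3-(fluorosulfonyl)phenyl in place of 4-(fluorosulfonyl)phenyl on an amide-type nitrogen. Going by the values given here, no measured pair in this set moves the fluorosulfonyl group around the ring, so no step bears directly on this change; the only measured step, from compound 1 to compound 2, concerned a chloro and was within the scatter. The step is therefore expected to be small, with a slight lean downward, as a number 0.20 log units lower from compound 2 to compound 4 (within the scatter). Compound 4 is estimated at 7.4 in this assay, with a range from 6.9 to 7.9.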

Compound 4, logarithm of the reciprocal of the active concentration, log(1/C): 7.74
Compound 4: the middle estimate sits 0.34 log units below what was measured; measured number inside the range.
By their numbers in this assay, from the lowest: compounds 2, 1, 4 and 3 (each within the scatter of the next).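

In this assay, the exchange of 4-(fluorosulfonyl)phenyl for 3-(fluorosulfonyl)phenyl on the amide-type nitrogen gives a number 0.14 log units higher from compound 2 to compound 4 (within the scatter). For the compounds shown here, this is the first measured pair in the set that concerns the fluorosulfonyl group rather than a chloro, and it shows that this read-out does not separate the two arrangements of the same atoms. Nothing available bears on the reason for this result.

The compounds shown leave open whether a sulfonamide or a carboxylic acid in place of the fluorosulfonyl group would stay within the scatter of compound 4 in this assay. Going by these compounds, it also remains open whether a longer chain in place of the one carrying the amide would leave the two arrangements just as close.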